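The source may hold more compounds than are shown below. What is called first, only, known or untested is meant among the compounds shown, and "the series" means these compounds.

Measured in a functional assay on NIH3T3 cells (Mus musculus) for inhibition, read by MTT assay, with a stated time of 72 h; on this read-out lower numbers stand for stronger inhibition and higher numbers for weaker inhibition:
Compound 1 `C=C1CC[C@H]2[C@@](C)(CC[C@@H](O)[C@@]2(C)C(=O)OCc2ccccc2)[C@@H]1CCC1=CCOC1=O`: 37900 nM
Compound 2 `C=C1CC[C@H]2[C@@](C)(CC[C@@H](O)[C@@]2(C)C(=O)OC)[C@@H]1/C=C/C1=CCOC1=O`: 111000 nM

Compound 2 has the higher of the two numbers, and its gap to compound 1 lies beyond the usual scatter. Compound 3 `C=C1CC[C@H]2[C@@](C)(CC[C@@H](O)[C@@]2(C)C(=O)OCc2ccccc2)[C@@H]1/C=C/C1=CCOC1=O` has not yet been measured. It differs from compound 2 in one place: phenyl in place of hydrogen on a saturated chain carbon bound to an oxygen next to a carbonyl group, turning methoxycarbonyl into benzyloxycarbonyl. Among the compounds with values here, no measured pair isolates this change. Within the data shown here, the only guide carries benzyloxycarbonyl but differs from compound 3 elsewhere: it is compound 1, which gives 37900 nM. A moderate move towards a lower number, meaning stronger inhibition, is therefore expected in this assay. The expected size of this move is a 2.5-fold lower number from compound 2 to compound 3 (0.39 log units; beyond the scatter). The estimated value for compound 3 is 45000 nM, with a range of 18000 nM to 110000 nM.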

Compound 3, half-maximal inhibitory concentration: 13600 nM
Estimate against measurement, compound 3: 3.3-fold (0.52 log units) above; measured number outside the range, below it.
By their numbers in this assay, from the lowest: compound 3; then compound 1; then compound 2.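

In this assay, the change from methoxycarbonyl to benzyloxycarbonyl can now be read on its own: phenyl in place of hydrogen on a saturated chain carbon bound to an oxygen next to a carbonyl group gives an 8.2-fold lower number from compound 2 to compound 3 (0.91 log units; beyond the scatter), so this place accepts the phenyl with stronger inhibition. With benzyloxycarbonyl held fixed, changing the group of 8 heavy atoms on the saturated ring carbon gives a 2.8-fold lower number from compound 1 to compound 3 (0.45 log units; beyond the scatter), so that part of the structure also affects the read-out. Nothing available explains either step.

The compounds shown do not tell whether the first step depends on the aromatic ring or on the added carbons alone, as an ethyl ester or a cyclohexylmethyl ester could show. From the compounds shown here alone, how a free carboxylic acid would compare at this place also remains open.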